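A few compounds are considered here, and "the series" means these few. Any claim that something is new, unique, unknown or untested is made for them only; others in the source may bear on it.

Compound 1 `Cc1ccncc1C(=O)N1CC(Oc2cncc(N3C(=O)c4ccc(Cl)cc4C3(C)C)c2)C1`: 5.4 10^-6 cm/s
Compound 2 `CC1(C)c2cc(Cl)ccc2C(=O)N1c1cncc(N2CCN(S(C)(=O)=O)CC2)c1`: 6.03 10^-6 cm/s

Both compounds were measured in an ADME assay for permeability, using PAMPA, with a stated time of 18 h; on this read-out higher numbers stand for higher permeability and lower numbers for lower permeability. Compound 1 stands at 5.4 10^-6 cm/s, and compound 2 at 6.03 10^-6 cm/s lies within the usual scatter of it. Compound 3 `Cn1cc(C(=O)N2CC(Oc3cncc(N4C(=O)c5ccc(Cl)cc5C4(C)C)c3)C2)cn1` has not yet been measured. It departs from compound 1 by one change: 1-methyl-1H-pyrazol-4-yl in place of 4-methylpyridin-3-yl on a carbonyl carbon. For the measured compounds named here, no measured pair shows this change, so the expectation rests on compound 1 at 5.4 10^-6 cm/s alone. The expected move is slight, downward and no larger than the scatter: a 1.2-fold lower number from compound 1 to compound 3 (0.08 log units; within the scatter). For compound 3 the estimated value is 4.5 10^-6 cm/s, with an expected range from 1.8 10^-6 cm/s to 11 10^-6 cm/s.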

Compound 3, apparent permeability: 3.45 10^-6 cm/s
Beside the measured number, compound 3's estimate is 1.3-fold (0.12 log units) above it, and the stated range covers the measured number.
By their numbers in this assay, from the lowest: compounds 3, 1 and 2 (each within the scatter of the next).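

In this assay, 1-methyl-1H-pyrazol-4-yl in place of 4-methylpyridin-3-yl on a carbonyl carbon gives a 1.6-fold lower number from compound 1 to compound 3 (0.19 log units; within the scatter). This first one-place comparison shows that, at this position, a five-membered aromatic ring with two hetero atoms can replace a six-membered one with one hetero atom without a step beyond the scatter. Nothing available explains the result. Still open, from the compounds shown here alone, is whether a saturated ring such as piperidine, or a phenyl ring bearing a carboxylic acid, on that carbonyl carbon would give a step beyond the scatter.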